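The source may hold more compounds than are shown below. What is called first, only, known or untested is meant among the compounds shown, and "the series" means these compounds.

Compound 1 `CCOc1ccccc1-c1ccc(-c2nc3cnccc3c(N[C@H](CC)C(N)=O)c2C#N)cc1` gives 3 in a physicochemical assay for lipophilicity, read by HPLC, at pH 7.5; a lower number here means a more polar compound, a higher number a more lipophilic compound. Among the three measured compounds it stands second highest: compound 2 `CCOc1ccccc1-c1ccc(-c2nc3cnccc3c(N[C@H](CC(C)C)C(N)=O)c2C#N)cc1` gives 3.4, and compound 3 `CCOc1ccccc1-c1ccc(-c2nc3cnccc3c(N[C@H](CC)C(=O)NS(=O)(=O)C3CC3)c2C#N)cc1` gives 2.3. The steps connecting them are a number 0.40 log units higher from compound 1 to compound 2 (beyond the scatter), a number 0.70 log units lower from compound 1 to compound 3 (beyond the scatter) and a number 1.10 log units lower from compound 2 to compound 3 (beyond the scatter); every one of them alters the group carried by the nitrogen on the aromatic ring of the shared core, and nothing else.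

Compound 4 `CC[C@@H](Nc1c(C#N)c(-c2ccc(-c3ccccc3C(C)C)cc2)nc2cnccc12)C(N)=O` differs from compound 1 in a different region: isopropyl in place of ethoxy on an aromatic carbon. For the measured compounds named here, no measured step touches the 2-ethoxyphenyl part of the molecule, so none bears on this change directly. The nearest guide is a number 0.40 log units higher from compound 1 to compound 2 (beyond the scatter), in which one saturated chain group replaces a smaller one and the distribution coefficient moves up by a modest amount. With an ethoxy leaving and an isopropyl entering, a modest rise in this assay is expected, a number 0.50 log units higher from compound 1 to compound 4 (beyond the scatter). Compound 4 is therefore estimated at 3.5, with a range from 3.1 to 3.9.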

Compound 4, distribution coefficient: 3.5
For compound 4 middle estimate and measured number coincide at the digits printed; low and high end bracket the measured number.
By their numbers in this assay, from the lowest: compound 3; then compound 1; then compounds 2 and 4 (each within the scatter of the next).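

In this assay, for the compounds shown here, the change from 2-ethoxyphenyl to 2-isopropylphenyl gives a number 0.50 log units higher from compound 1 to compound 4 (beyond the scatter), the first measured step on the six-membered aromatic ring of carbon only, ortho to a large group. The earlier steps shown here all altered the group on the nitrogen, so this step shows that the number also responds to a change in this separate region, even with the heavy-atom count unchanged and a carbon entering in place of the ethoxy oxygen. No measurement on hand accounts for this rise.

Open, going by these compounds, is whether the step keeps its size with the cyclopropylsulfonyl amide of compound 3 on the other side of the molecule. Also open, on these data alone, is how methoxy, tert-butyl, dimethylamino or a carboxylic acid would read at this same place.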